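From trifluoromethyl to benzyloxy on a shared core

The source may hold more compounds than are shown below. What is called first, only, known or untested is meant among the compounds shown, and "the series" means these compounds.

In a functional assay on U-87MG ATCC cells for inhibition, with U-87 MG (Homo sapiens) as the target, read by MTT assay, with a stated time of 72 h (on this read-out lower numbers stand for stronger inhibition and higher numbers for weaker inhibition), compound 1 `Cc1ccnc(NC(c2ccc(C(F)(F)F)cc2)c2ccc3cccnc3c2O)c1` gives 2100 nM, the lowest of the two true numbers available. Compound 3 `Cc1ccnc(NC(c2cccc(F)c2)c2ccc3cccnc3c2O)c1` gives 9200 nM. Compound 2 `COc1ccc(C(Nc2cc(C)ccn2)c2ccc3cccnc3c2O)cc1O` is recorded as > 10000 nM, which is a limit of the assay and not a number.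

Compound 4 `Cc1ccnc(NC(c2ccc(OCc3ccccc3)cc2)c2ccc3cccnc3c2O)c1` has not yet been measured. It keeps the core of compound 1 and changes in one place: benzyloxy in place of trifluoromethyl on an aromatic carbon.

Within the data shown here, two measured steps bear on this change, each replacing the whole 4-(trifluoromethyl)phenyl group: an at least 4.7-fold higher number from compound 1 to compound 2 (0.67 log units; beyond the scatter), and a 4.4-fold higher number from compound 1 to compound 3 (0.64 log units; beyond the scatter). Both lie beyond the scatter and point the same way. Neither introduces benzyloxy, however, so they suggest a direction but fix the size only loosely. A modest step towards a higher number is therefore expected in this assay, and the estimate is a 2.4-fold higher number from compound 1 to compound 4 (0.38 log units; beyond the scatter). For compound 4 the estimated value is 5000 nM, with an expected range from 1500 nM to 10000 nM.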

Compound 4, half-maximal inhibitory concentration: 9300 nM
Estimate against measurement, compound 4: 1.9-fold (0.27 log units) below, and the stated range covers the measured number.
By their numbers in this assay, from the lowest: compound 1; then compounds 3 and 4 (each within the scatter of the next). At a limit, above all of these: compound 2.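

In this assay, among these compounds, this is the first step that leaves the aromatic ring of compound 1 in place and alters only the group on it, para to a large group: benzyloxy in place of trifluoromethyl gives a 4.4-fold higher number from compound 1 to compound 4 (0.65 log units; beyond the scatter). The change thus reaches beyond the scatter on its own, without the whole 4-(trifluoromethyl)phenyl group being replaced. Bringing in a further aromatic ring and a hydrogen-bond acceptor at this place gave no lower number, and all three replacements shown leave compound 1 with the lowest number, with no compound going against this.

On these data alone, whether a chlorine, a nitrile or an amine on this aromatic carbon would keep the number of compound 1 stays open. As far as these compounds go, compound 2 gives only a limit, so its place relative to compound 4 also stays open: the limit of > 10000 nM in this assay, at which 1 of the 4 values shown sits.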